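The source may hold more compounds than are shown below. What is called first, only, known or untested is meant among the compounds shown, and "the series" means these compounds.

Measured so far in a functional assay on NCI-H460 cells (Homo sapiens) for inhibition, read by sulforhodamine B assay, with a stated time of 48 h; a higher number here means a weaker inhibitor of growth, a lower number a stronger inhibitor of growth:
compound 1 `COC(=O)c1sc2cc(C#Cc3ccccn3)cnc2c1N` gives 34900 nM
compound 2 `COC(=O)c1sc2cc(C#Cc3ccc(N)cc3)cnc2c1N` gives 8900 nM

Compound 1 holds the highest number of the two; its nearest neighbour is compound 2, reached by a 3.9-fold lower number from compound 1 to compound 2 (0.59 log units; beyond the scatter). Compound 3 `COC(=O)c1sc2cc(C#Cc3ccccc3OC)cnc2c1N` is still unmeasured; its change from compound 1 is 2-methoxyphenyl in place of pyridin-2-yl on a triple-bonded carbon. Going by the values given here, only the step from compound 1 to compound 2 bears on this, a modest lowering after an exchange at the same triple-bonded carbon, though the entering group there was a different one. A modest lowering, or none beyond the scatter, is therefore expected. For compound 3 the expected number is 20000 nM, with a range of 6000 nM to 50000 nM, which means an expected step of a 1.7-fold lower number from compound 1 to compound 3 (0.24 log units; within the scatter).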

Compound 3, concentration for 50% growth inhibition: > 47300 nM
Compound 3 was reported as a limit (the forecaster's own chance of this, stated with the estimate: 5%); middle value at least 2.3-fold (0.37 log units) away from the limit.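

In this assay compound 3 gives > 47300 nM, which is a limit of the assay and not a number. A phenyl ring on the triple-bonded carbon therefore does not by itself bring the lower number of compound 2: 2-methoxyphenyl in place of 4-aminophenyl gives an at least 5.3-fold higher number from compound 2 to compound 3 (0.72 log units; beyond the scatter). Against pyridin-2-yl the exchange gives an at least 1.3-fold higher number from compound 1 to compound 3 (0.13 log units; that floor lies within the scatter), so no order between these two groups can be read.

On these data alone, whether the lower number of compound 2 depends on its amine remains open. A hydroxyl group or a carboxylic acid in place of that amine would bear on this.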